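This account rests on a few compounds, and the source may have more. Where it says the series, first, only, none or still open, it means among the compounds named here.

Working notes on the series. The shared core carries a thiourea-urea chain, and three members have been run in a physicochemical assay for lipophilicity, in phosphate buffer, measured as octanol-water partition; on this read-out lower numbers stand for lower lipophilicity and higher numbers for higher lipophilicity. Compound 1 `O=C(NC(=S)Nc1ccccc1)Nc1ccc2c(c1)C(=O)C(=O)N2Cc1ccccc1`, bearing an unsubstituted phenyl on the thiourea nitrogen, gives 2.48. Compound 2 `Cc1cccc(NC(=S)NC(=O)Nc2ccc3c(c2)C(=O)C(=O)N3Cc2ccccc2)c1` gives 2.92, and compound 3 `Cc1ccc(NC(=S)NC(=O)Nc2ccc3c(c2)C(=O)C(=O)N3Cc2ccccc2)cc1` gives 2.96. Among these three numbers compound 2 stands second highest; its nearest neighbour is compound 3, which is within the scatter of it, while compound 1 lies furthest from it, beyond the scatter.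

The steps seen so far: a number 0.44 log units higher from compound 1 to compound 2 (beyond the scatter); a number 0.48 log units higher from compound 1 to compound 3 (beyond the scatter); and a number 0.04 log units higher from compound 2 to compound 3 (within the scatter), so the two methyl positions on the phenyl read alike in this assay.

Compound 4 `COc1ccccc1NC(=S)NC(=O)Nc1ccc2c(c1)C(=O)C(=O)N2Cc1ccccc1` has not yet been measured. The change from compound 2 is 2-methoxyphenyl in place of 3-methylphenyl on an amide-type nitrogen. Going by the values given here, no measured step exchanges a methyl for a methoxy, so the bearing of the methyl steps is indirect: they show the methyl adding a modest amount to compound 1, and the methoxy brings one hydrogen-bond acceptor into the same place. The expectation is therefore a modest step downward in this assay from compound 2 to compound 4, estimated as a number 0.32 log units lower from compound 2 to compound 4 (beyond the scatter), landing near compound 1. Compound 4 is estimated at 2.6, with a range from 2.25 to 2.95.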

Compound 4, partition coefficient: 2.38
The estimate for compound 4 lay 0.22 log units above the measured number; measured number inside the range.
By their numbers in this assay, from the lowest: compounds 4 and 1 (each within the scatter of the next); then compounds 2 and 3 (each within the scatter of the next).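

In this assay, the methyl steps did not show whether any substituent on this phenyl would read like methyl; 2-methoxyphenyl on the amide-type nitrogen separates clearly from 3-methylphenyl, at a number 0.54 log units lower from compound 2 to compound 4 (beyond the scatter), and from 4-methylphenyl, at a number 0.58 log units lower from compound 3 to compound 4 (beyond the scatter). Methoxy in place of hydrogen gives a number 0.10 log units lower from compound 1 to compound 4 (within the scatter), so on this read-out the added methoxy leaves the number indistinguishable from that of the unsubstituted phenyl, whereas each methyl moved it beyond the scatter; the series therefore shows that substitution on this phenyl does not shift the number in the same way for every group. No supporting measurement accounts for this difference between methoxy and methyl.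

The compounds shown leave open whether the step follows the methoxy group or its position on the phenyl, since group and position change together between the methylphenyl compounds and compound 4. On these data alone, how a phenyl carrying an amine, a carboxylic acid or a longer alkoxy chain would read on the same nitrogen also remains open.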